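Fluoro in place of the amide on the aryl ring

This account rests on a few compounds, and the source may have more. Where it says the series, first, only, none or still open, it means among the compounds named here.

Compound 1: `COc1ccc(/C=C2\SC(c3ccc(NC(=O)CCc4ccccc4)cc3)=NC2=O)cc1` — 11100 nM
Compound 2: `CCC(=O)Nc1ccc(C2=NC(=O)/C(=C/c3ccc(OC)cc3)S2)cc1` — 760 nM

In an assay on PMNL cells for inhibition of Polyunsaturated fatty acid 5-lipoxygenase (Homo sapiens), read by HPLC, with stated times of 15 min and 10 min (on this read-out higher numbers stand for weaker inhibition and lower numbers for stronger inhibition), compound 1 gives 11100 nM, while compound 2 gives 760 nM. The only measured step, a 15-fold lower number from compound 1 to compound 2 (1.16 log units; beyond the scatter), is the single one shown here, and it leaves compound 2 with the lowest number of the two compounds measured. Compound 3, `COc1ccc(/C=C2\SC(c3ccc(F)cc3)=NC2=O)cc1`, has not yet been measured in this assay. It differs from compound 2 in one place: fluoro in place of propanoylamino on an aromatic carbon. For the measured compounds named here, no measured step bears directly on this change; the one step known concerns the far end of the amide-bearing chain, whereas here the whole propanoylamino group leaves and a single fluoro enters in its place. Going by the values given here, because the one measured step, a 15-fold lower number from compound 1 to compound 2 (1.16 log units; beyond the scatter), concerns a different part of the molecule, there is no basis for expecting a large move in either direction. Compound 3 is therefore expected to give 1500 nM, within a range of 400 nM to 6000 nM. This estimate corresponds to an expected step of a 2.0-fold higher number from compound 2 to compound 3 (0.30 log units; within the scatter), which would sit close to the scatter of repeated measurements.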

Compound 3, half-maximal inhibitory concentration: 550 nM
Compound 3: the middle estimate sits 2.7-fold (0.44 log units) above what was measured; the range from low to high includes it.
By their numbers in this assay, from the lowest: compounds 3 and 2 (each within the scatter of the next); then compound 1.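

In this assay, the step of a 1.4-fold lower number from compound 2 to compound 3 (0.14 log units; within the scatter) shows that this aromatic carbon, para to a large group, does not need the amide to keep the number in the range of compound 2. The propanoylamino group, with its 5 heavy atoms, 1 hydrogen-bond donor and 1 hydrogen-bond acceptor, gives way to a single fluoro with neither donor nor acceptor, and the two compounds cannot be told apart in this read-out. The earlier step, a 15-fold lower number from compound 1 to compound 2 (1.16 log units; beyond the scatter), had shown only that the phenyl on the chain carries a large penalty, whereas this change removes the whole chain with no step beyond the scatter, and no separate measurement is at hand to explain the result.

The compounds shown leave open whether a hydrogen, a chloro or an amine on this same aromatic carbon would also stay within the scatter of fluoro and propanoylamino. They also leave open whether the methoxy group shared by all three compounds could give way to a hydroxyl or a carboxylic acid without moving the number.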